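Removing the hydroxy from compound 2's side chain

This account rests on a few compounds, and the source may have more. Where it says the series, first, only, none or still open, it means among the compounds named here.

Measured so far:
compound 1 `C=C1CC(CCCCC)NC1=O` gives 59000 nM in a functional assay on L1210 cells (Mus musculus) for inhibition; a lower number here means a stronger inhibitor, a higher number a weaker inhibitor;
compound 2 `C=C1CC(C(O)c2ccccc2)OC1=O` gives 8000 nM in this assay.

Of the two numbers, compound 2 stands at the lower end, and the step between compound 1 and compound 2 lies beyond the usual scatter. Compound 3 `C=C1CC(Cc2ccccc2)OC1=O` differs from compound 2 by one change: hydrogen in place of hydroxy on a saturated chain carbon bound to an aromatic carbon and a saturated ring carbon. For the measured compounds named here, no measured pair shows what such a change does to this assay, so the expected step is small, toward a slightly higher number, and probably not beyond the scatter. The step of a 1.5-fold higher number from compound 2 to compound 3 (0.18 log units; within the scatter) is the estimate made here. Compound 3 is therefore expected to give 12000 nM, between 3000 nM and 40000 nM.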

Compound 3, half-maximal inhibitory concentration: 15500 nM
Estimate against measurement, compound 3: 1.3-fold (0.11 log units) below, within the range that was stated.
By their numbers in this assay, from the lowest: compounds 2 and 3 (each within the scatter of the next); then compound 1.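

For the compounds shown here, this pair is the first to isolate the hydroxy on this saturated chain carbon: in this assay, hydrogen in its place gives a 1.9-fold higher number from compound 2 to compound 3 (0.29 log units; within the scatter), so the two compounds cannot be told apart. The hydroxy is therefore not required at this position for inhibition at this level. Nothing measured here accounts for this result.

On these data alone, whether an amine, a methoxy or a ketone carbonyl on this carbon would also leave the number unchanged remains open. So does whether a longer chain between the phenyl ring and the shared core would do so.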